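Swapping a Ring Ether for a Trifluoropropyl Chain

The source may hold more compounds than are shown below. What is called first, only, known or untested is meant among the compounds shown, and "the series" means these compounds.

Measured so far:
compound 1 `CC[C@@H]1C(=O)N(C)c2cnc(-n3ccnc3-c3ccc(F)cc3)nc2N1[C@H]1CCOC1`: 58%
compound 2 `CC[C@@H]1C(=O)N(C)c2cnc(-n3ccnc3-c3ccccc3)nc2N1[C@H]1CCOC1`: 17%
compound 3 `CC[C@@H]1C(=O)N(C)c2cnc(-n3ccnc3-c3ccccc3)nc2N1[C@@H]1CCOC1`: 10%

In an ADME assay on microsomes from liver (Homo sapiens) for metabolic stability, with a stated time of 30 min, tested at 1 uM (a lower number here means that less of the compound is left, a higher number that more of the compound is left), compound 1 gives the highest of the three numbers, a number 41 percentage points lower from compound 1 to compound 2 (beyond the scatter) and a number 7 percentage points lower from compound 2 to compound 3 (within the scatter). Compound 4 `CC[C@@H]1C(=O)N(C)c2cnc(-n3ccnc3-c3ccc(F)cc3)nc2N1CCC(F)(F)F` is not yet measured; it differs from compound 1 in one place: 3,3,3-trifluoropropyl in place of oxolan-3-yl on a nitrogen on an aromatic ring in a ring. For the measured compounds named here, no measured step replaces the oxolan-3-yl group with anything else. Going by the values given here, the only step that touches that group is the one from compound 2 to compound 3, where only the configuration changed, and the number moved within the scatter; the step from compound 1 to compound 2 concerns the fluoro and does not bear on this change. The expected step is therefore uncertain and a number 13 percentage points lower from compound 1 to compound 4 (beyond the scatter) is estimated as a moderate drop. Compound 4 is expected to give about 45%, within 15% to 75%.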

Compound 4, percent of the compound remaining in the Homo sapiens assay: 27%
For compound 4 the middle estimate is 18 percentage points above the measured one; the range from low to high includes it.
By their numbers in the Homo sapiens assay, from the lowest: compounds 3, 2 and 4 (each within the scatter of the next, the first and the last beyond it); then compound 1.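

On this nitrogen, the group matters in the Homo sapiens assay: with the open 3,3,3-trifluoropropyl chain in place of the oxolan-3-yl ring, the result is a number 31 percentage points lower from compound 1 to compound 4 (beyond the scatter). The earlier compounds shown here could not show this, since they changed only the drawn configuration of that ring: the fact that compounds 2 and 3 differ only in the configuration as drawn. In a physicochemical assay for lipophilicity (on this read-out lower numbers stand for lower lipophilicity and higher numbers for higher lipophilicity), compound 1 gives 2 and compound 4 gives 3.1, but this single pair cannot tell whether the two read-outs are linked.

From the compounds shown here alone, it remains open whether a plain propyl chain or a cyclopentyl ring would leave more compound after incubation, which would help separate the roles of the ring, its oxygen and the fluorines.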